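A few compounds are considered here, and "the series" means these few. Any claim that something is new, unique, unknown or untested is made for them only; others in the source may bear on it.

Values in a functional assay on DU-145 cells (Homo sapiens), read by sulforhodamine B assay, with a stated time of 5 days; on this read-out higher numbers stand for weaker inhibition of growth and lower numbers for stronger inhibition of growth:
- compound 1 `OC[C@H]1O[C@@H](n2cc(F)c3c(-c4ccco4)ncnc32)[C@H](O)[C@@H]1O`: 5 nM
- compound 2 `OC[C@H]1O[C@@H](n2cc(F)c3c(-c4cccs4)ncnc32)[C@H](O)[C@@H]1O`: 9 nM
- compound 3 `OC[C@H]1O[C@@H](n2cc(F)c3c(-c4ccc[nH]4)ncnc32)[C@H](O)[C@@H]1O`: 9 nM

Compound 1, at 5 nM, is not set apart from the other two, as both of its steps stay within the scatter. The next compound is compound 4 `OC[C@H]1O[C@@H](n2cc(F)c3c(-c4c[nH]cn4)ncnc32)[C@H](O)[C@@H]1O`, where 1H-imidazol-4-yl stands in place of furan-2-yl on an aromatic carbon: 1H-imidazol-4-yl in place of furan-2-yl on an aromatic carbon.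

For the measured compounds named here, the steps that bear on this exchange are a 1.8-fold higher number from compound 1 to compound 2 (0.26 log units; within the scatter) and a 1.8-fold higher number from compound 1 to compound 3 (0.26 log units; within the scatter), along with no change at the digits printed from compound 2 to compound 3 (within the scatter). Each swaps one five-membered aromatic ring for another at the same place, and none exceeds the scatter in this assay. Going by the values given here, no measured compound carries 1H-imidazol-4-yl, so the data do not test this group directly. A small move towards a higher number is therefore expected, and no change remains possible. The estimated step is a 3.0-fold higher number from compound 1 to compound 4 (0.48 log units; beyond the scatter). For compound 4 the expected value is 15 nM, with an estimated range of 5 nM to 80 nM.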

Compound 4, concentration for 50% growth inhibition: 890 nM
Compound 4: middle estimate off by 59-fold (1.77 log units), on the low side; the whole stated range lies below it.
By their numbers in this assay, from the lowest: compounds 1, 2 and 3 (each within the scatter of the next); then compound 4.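

In this assay, for the compounds shown here, this place on the six-membered aromatic ring proves far less permissive than the earlier compounds suggested, with 1H-imidazol-4-yl giving a 180-fold higher number from compound 1 to compound 4 (2.25 log units; beyond the scatter) and a 99-fold higher number from compound 2 to compound 4 (2.00 log units; beyond the scatter) and a 99-fold higher number from compound 3 to compound 4 (2.00 log units; beyond the scatter). A five-membered aromatic ring at this place is therefore no guarantee of a low number, and since compound 3 also has a hydrogen on a ring nitrogen, that feature alone does not separate compound 4 from the others. Nothing at hand gives a reason for this large loss.

Compound 4 differs from the others both in having 2 hetero atoms in this ring and in its 4-yl attachment, and these two changes remain unseparated. On these data alone, whether 1H-imidazol-2-yl, 1H-pyrazol-3-yl or oxazol-2-yl at the same place would stay with compounds 1 to 3 or with compound 4 remains open.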